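A few compounds are considered here, and "the series" means these few. Any claim that something is new, unique, unknown or untested is made for them only; others in the source may bear on it.

Measured in a functional assay on HUVEC cells (Homo sapiens) for antiproliferative activity, read by MTT assay, with a stated time of 72 h; a lower number here means a stronger inhibitor, a higher number a weaker inhibitor:
- compound 1 `COc1cc(C2Oc3cc(-c4oc5cc(O)cc(O)c5c(=O)c4OC)ccc3OC2CO)ccc1O`: 4900 nM
- compound 2 `COc1cc(C2Oc3cc(-c4oc5cc(O)cc(O)c5c(=O)c4O)ccc3OC2CO)ccc1OC(=O)c1cc(O)c(O)c(O)c1`: 4000 nM
- compound 3 `COc1cc(C2Oc3cc(-c4oc5cc(OC(=O)c6cc(O)c(O)c(O)c6)cc(O)c5c(=O)c4O)ccc3OC2CO)ccc1O`: 1600 nM

These three compounds share a core but carry different decorations. In this assay, compound 1 gives 4900 nM. That places it within the usual scatter of compound 2, so the two cannot be told apart here. Compound 3 has a lower number, and its gap to compound 1 lies beyond the scatter.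

The next compound to be tested is compound 4 `COc1cc(O)c2c(=O)c(OC)c(-c3ccc4c(c3)OC(c3ccc(O)c(OC)c3)C(CO)O4)oc2c1`. Compared with compound 1, it carries one small change: methyl in place of hydrogen on an oxygen on an aromatic ring. This is methyl in place of hydrogen on an oxygen on an aromatic ring, or hydroxy to methoxy.

For the measured compounds named here, no two measured compounds differ in only one place, so the data give no direct measure of what such a change does. With nothing to suggest a large shift, the expectation stays close to compound 1 at 4900 nM, and no step beyond the scatter is expected in this assay. The expected step is a 1.0-fold higher number from compound 1 to compound 4 (0.01 log units; within the scatter). For compound 4 the estimated value is 5000 nM, with an expected range from 2000 nM to 12000 nM.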

Compound 4, half-maximal inhibitory concentration: 8300 nM
Beside the measured number, compound 4's estimate is 1.7-fold (0.22 log units) below it, within the range that was stated.
By their numbers in this assay, from the lowest: compound 3; then compounds 2, 1 and 4 (each within the scatter of the next, the first and the last beyond it).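

For the compounds shown here, this is the first pair in the set that differs in one place, so the change from hydroxy to methoxy can be read directly in this assay as a 1.7-fold higher number from compound 1 to compound 4 (0.23 log units; within the scatter) and no more than that. The step lies within the usual scatter of repeated measurements, so methyl in place of hydrogen on this oxygen on an aromatic ring gives a compound that cannot be told apart from its parent in this assay. The hydrogen on this oxygen therefore is not shown to matter for the read-out, and no other measurement is at hand to help explain this result.

From the compounds shown here alone, whether a larger group on this same oxygen, such as an ethyl group or a benzyl group, would also stay within the scatter remains open, as does what an amine in place of the hydroxy group would do. The other compounds differ from compound 1 in more than one place, so their steps cannot be read as the effect of any single change.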